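Chain shortening on the core: compound 4 ahead of measurement

The compounds below may be only part of what the source reports. "The series", "measured", "known", "first", "only" and "open" are said of these compounds alone.

Measured in a functional assay on U-937 cells (Homo sapiens) for cytotoxicity, read by MTT assay, with a stated time of 24 h; on this read-out higher numbers stand for weaker inhibition and lower numbers for stronger inhibition:
Compound 1, `CCCCCCCCCCn1cc(-c2nc3ccccc3cc2C)nn1`: compound 1 gives > 100 ug/mL, a limit of the assay.
Compound 2, `Cc1cc2ccccc2nc1-c1cn(CCC(F)(F)C(F)(F)C(F)(F)C(F)(F)C(F)(F)C(F)(F)C(F)(F)C(F)(F)F)nn1`: compound 2 gives 56.6 ug/mL.
Compound 3, `CCCCCc1cc2ccccc2nc1-c1cn(CCC(F)(F)C(F)(F)C(F)(F)C(F)(F)C(F)(F)C(F)(F)C(F)(F)C(F)(F)F)nn1`: compound 3 gives > 100 ug/mL, a limit of the assay.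

Compound 3 thus stands only at a limit, as does compound 1; compound 2 alone gives a number. Compound 4, `CCc1cc2ccccc2nc1-c1cn(CCC(F)(F)C(F)(F)C(F)(F)C(F)(F)C(F)(F)C(F)(F)C(F)(F)C(F)(F)F)nn1`, differs from compound 3 by hydrogen in place of propyl on a saturated chain carbon, two bonds along the chain from an aromatic carbon. Among the measured compounds shown here, the one measured step that bears on it is an at least 1.7-fold higher number from compound 2 to compound 3 (0.24 log units; that floor lies within the scatter), a step whose floor lies within the scatter. Going the other way, toward a shorter chain, the expected step of an at least 1.2-fold lower number from compound 3 to compound 4 (0.09 log units; that floor lies within the scatter) is therefore small, at most a modest lowering from the limit. Compound 4 is estimated at 80 ug/mL, with a range from 40 ug/mL to 150 ug/mL.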

Compound 4, half-maximal inhibitory concentration: 55.9 ug/mL
The estimate for compound 4 lay 1.4-fold (0.16 log units) above the measured number; the measured number falls inside the stated range.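

Ethyl at this position gives a readable number in this assay, where pentyl gave only a limit, and the step is an at least 1.7-fold lower number from compound 3 to compound 4 (0.25 log units; that floor lies within the scatter). Methyl and ethyl cannot be told apart at this position: a 1.0-fold lower number from compound 2 to compound 4 (0.01 log units; within the scatter). The full size of the pentyl to ethyl change stays unknown because compound 3 sits at a limit: the limit of > 100 ug/mL in this assay, at which 2 of the 4 values shown sit.

The compounds shown leave open where along the chain the readable number gives way to the limit, as propyl and butyl are not among them. They also leave open how an amine or a carboxylic acid at this position would read.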